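Aryl trifluoromethyl in place of methyl: writhing test outlook

The compounds below may be only part of what the source reports. "The series", "measured", "known", "first", "only" and "open" are said of these compounds alone.

Compound 1 `Cc1ccc(-c2cc(C)n(S(=O)(=O)Oc3ccccc3)n2)cc1` gives 50.7% in a functional assay on the whole organism for inhibition, with Mus musculus as the target, in the writhing test, with stated times of 3 days and 20 min, at a dose of 30 mg/kg by the oral route (a lower number here means less inhibition, a higher number more inhibition at the dose given (going by the name of the read-out)), the highest of the three numbers. Compound 3 `Cc1ccc(-c2cc(C)n(S(=O)(=O)Oc3ccccc3Cl)n2)cc1` gives 48.5%, and the step of a number 2.2 percentage points lower from compound 1 to compound 3 (within the scatter) lies within the scatter. Compound 2 `Cc1ccc(-c2cc(C)n(S(=O)(=O)Oc3ccc(I)cc3)n2)cc1` gives 17.2%, reached by a number 33.5 percentage points lower from compound 1 to compound 2 (beyond the scatter). Compound 4 `Cc1cc(-c2ccc(C(F)(F)F)cc2)nn1S(=O)(=O)Oc1ccccc1` differs from compound 1 by trifluoromethyl in place of methyl on an aromatic carbon. All measured steps, including a number 31.3 percentage points higher from compound 2 to compound 3 (beyond the scatter), alter the ring on the oxygen, not the ring on the shared core where the new group sits, so none bears directly on this change. Within the data shown here, with no step at the relevant position, the expectation is a change not beyond the scatter, a number 5.7 percentage points lower from compound 1 to compound 4 (within the scatter), carrying wide uncertainty. Compound 4 is therefore estimated at 45%, within a range of 20% to 65%.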

Compound 4, a percentage reported as inhibition, in the whole organism at one dose (the size of the read-out at that dose, not a potency): 25.8%
For compound 4 the middle estimate is 19.2 percentage points above the measured one, within the range that was stated.
By their numbers in this assay, from the lowest: compounds 2 and 4 (each within the scatter of the next); then compounds 3 and 1 (each within the scatter of the next).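

Among these compounds, the ring on the shared core, which no earlier step touched, is not silent in this assay: trifluoromethyl in place of methyl, para to a large group, gives a number 24.9 percentage points lower from compound 1 to compound 4 (beyond the scatter). The read-out at this dose therefore responds to this position as well as to the ring on the oxygen. No available data account for this drop.

Still open, on these data alone, is how a methoxy group or an amine at this place would read out, and thus whether the drop is specific to trifluoromethyl. Also open, as far as these compounds go, is how trifluoromethyl here would combine with a chloro group on the ring on the oxygen.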